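The source may report more compounds than this note shows. Statements on the series, on what has been measured and on what is new or still open speak of the compounds shown alone.

Working notes on the series.

Three compounds have been run so far in a functional assay on COLO 205 cells (Homo sapiens) for inhibition, read by sulforhodamine B assay, with a stated time of 48 h, tested at 50 uM; a higher number here means more inhibition of growth at the concentration tested, a lower number less inhibition of growth. Compound 1, `O=C1C(=O)N(CCCCCn2cc(COc3cc(=O)oc4ccccc34)nn2)c2ccc(F)cc21`, gives 56%. Compound 2, `O=C1C(=O)N(CCCCCn2cc(COc3cc(=O)oc4ccccc34)nn2)c2ccc(I)cc21`, gives 30%. Compound 3, `O=C1C(=O)N(CCCn2cc(COc3cc(=O)oc4ccccc34)nn2)c2ccc(I)cc21`, gives 56%.

One single-point change is available within the measured set. Going from compound 2 to compound 1 the change is fluoro in place of iodo on an aromatic carbon, and the read-out moves by a number 26 percentage points higher from compound 2 to compound 1 (beyond the scatter). No cause for this step is assigned here.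

Compound 3 and compound 2 differ by more than one place, and the difference between the two cores is not broken down here. Their values alone show compound 3 higher than compound 2 by an amount beyond the scatter, while compound 3 and compound 1 agree at the digits given and lie within the scatter of each other; no order between those two is claimed.

Compound 4, `O=C1C(=O)N(CCCn2cc(COc3cc(=O)oc4ccccc34)nn2)c2ccc(F)cc21`, has not yet been measured. From compound 3 it differs by fluoro in place of iodo on an aromatic carbon. Among the compounds with values here, this is the same change as the one from compound 2 to compound 1, at a place described in identical words, made on the core of compound 3 rather than on the core of compound 2.

For compound 4 in this assay the step from compound 3 is expected to be a number 14 percentage points higher from compound 3 to compound 4 (beyond the scatter), resting on the earlier step of a number 26 percentage points higher from compound 2 to compound 1 (beyond the scatter), tempered by the fact that the change is seen only once and that compound 3 already sits at the top of the measured set. The estimate for compound 4 is 70%, with a range from 50% to 88%.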

Compound 4, percent growth inhibition at one concentration: 69%
The estimate for compound 4 lay 1 percentage points above the measured number, within the range that was stated.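

this assay The fluoro-for-iodo change on the core of compound 3 gives a number 13 percentage points higher from compound 3 to compound 4 (beyond the scatter), in the same direction as the earlier a number 26 percentage points higher from compound 2 to compound 1 (beyond the scatter) on the core of compound 2. Set side by side, the two steps agree in direction and cannot be told apart in size: the same change on two cores in this assay, a number 26 percentage points higher (beyond the scatter) from compound 2 to compound 1 and a number 13 percentage points higher (beyond the scatter) from compound 3 to compound 4, 13 percentage points apart, within the scatter of two such steps This shows that, on these two cores, the change carried over with its sign intact, but two cores are a narrow base, so it does not establish a fixed size for the step, a rule for other cores in the series, or any reason for the rise.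

The compounds shown leave open where chloro, bromo or methoxy would fall on the same aromatic carbon, and so whether the read-out follows any order across substituents or simply separates fluoro from iodo. Also open, going by these compounds, is whether the step survives on a core with a chain longer than that of compound 1 or with an amine in the chain, and whether a reading at a single concentration would hold up across a full concentration range.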